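A few compounds are considered here, and "the series" means these few. Any claim that something is new, unique, unknown or untested is made for them only; others in the source may bear on it.

Compound 1 `CC(=O)Nc1cccc2c1CCCC2c1c[nH]cn1` carries an acetamido group on the shared core. In an assay on isolated protein (Cricetulus griseus) for binding affinity to Alpha-1B adrenergic receptor (Mesocricetus auratus), read by radioligand binding (on this read-out lower numbers stand for stronger inhibition and higher numbers for weaker inhibition), compound 1 gives < 10000 nM, which is a limit of the assay rather than a measured number. Two related compounds were tested alongside it. Compound 2 `CS(=O)(=O)Nc1ccc(F)c2c1CCCC2c1c[nH]cn1` carries a methanesulfonamide group together with a fluoro substituent. In this assay compound 2 gives < 10000 nM, again only a limit. Compound 3 `COc1ccc(NS(C)(=O)=O)c2c1C(c1c[nH]cn1)CCC2` has a methoxy in place of fluoro on an aromatic carbon. In this assay compound 3 gives < 10000 nM, also a limit. Going by the values given here, the one step that can be drawn between measured compounds, a step that the two limits leave unreadable from compound 2 to compound 3, therefore has no readable size. All three results sit at the same limit (the limit of < 10000 nM in this assay, at which 3 of the 3 values shown sit), so compound 1 cannot be ranked against its neighbours and is known only to lie within what that limit marks.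

Compound 4 `Nc1cccc2c1CCCC2c1c[nH]cn1` differs from compound 1 by hydrogen in place of acetyl on a nitrogen on an aromatic ring. Among the compounds with values here, no measured step carries information on this change, as every value shown is a limit and the single computed step is unreadable. The expectation for compound 4 must therefore stay wide: compound 4 is estimated at 2000 nM, somewhere between 300 nM and 10000 nM. The step this estimate implies, a step that the limit leaves unreadable from compound 1 to compound 4, is itself expected to be no more than a guess, with no direction favoured.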

Compound 4, inhibition constant: 525 nM
For compound 4 the middle estimate is 3.8-fold (0.58 log units) above the measured one, and the stated range covers the measured number.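

Compound 4 now has a measured number, but compound 1 is known only as a limit, so the change from compound 1 to compound 4 has no readable size: the limit of < 10000 nM in this assay, at which 3 of the 4 values shown sit.

Whether going from acetamido to amino strengthens, weakens or leaves unchanged the inhibition in this assay stays open among the compounds shown.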